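Adding bromo to compound 1

A few compounds are considered here, and "the series" means these few. Any claim that something is new, unique, unknown or untested is made for them only; others in the source may bear on it.

- compound 1 `O/N=C(\COc1cccc2ccccc12)c1ccccc1`: 47100 nM
- compound 2 `O/N=C(\COc1cccc2ccccc12)c1ccc(Cl)cc1`: > 50000 nM, a limit of the assay

Within the data shown here, in an ADME assay on NCI-H226 cells (Homo sapiens) for cytotoxicity, read by MTT assay (on this read-out higher numbers stand for weaker inhibition and lower numbers for stronger inhibition), compound 1 gives 47100 nM, the only actual number so far. Compound 3 `O/N=C(\COc1cccc2ccccc12)c1ccc(Br)cc1` differs from it by bromo in place of hydrogen on an aromatic carbon. Among the measured compounds shown here, the one measured step bearing on this is the chloro change, an at least 1.0-fold higher number from compound 1 to compound 2 (0.02 log units; that floor lies within the scatter). Going by these compounds, that step ends at the limit of > 50000 nM in this assay, at which 1 of the 2 values shown sits, so its true size stays open. With that chloro step as the guide, no change beyond the scatter is firmly expected in this assay, and any lean would be towards higher numbers. The expected step is a 1.1-fold higher number from compound 1 to compound 3 (0.03 log units; within the scatter). Compound 3 is estimated at 50000 nM, with an expected range of 28000 nM to 90000 nM.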

Compound 3, half-maximal inhibitory concentration: > 50000 nM
Compound 3 ended at the assay's limit (the forecaster's own chance of this, stated with the estimate: 50%); the middle value sits exactly at the limit.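

In this assay, the change from phenyl to 4-bromophenyl gives an at least 1.0-fold higher number from compound 1 to compound 3 (0.02 log units; that floor lies within the scatter), so a second halogen on this aromatic carbon, para to a large group, also yields no readable number. Chloro and bromo therefore cannot be ordered, and the step between compound 2 and compound 3 cannot be read: the limit of > 50000 nM in this assay, at which 2 of the 3 values shown sit.

Going by these compounds, whether either halogen shifts the value beyond the scatter remains open. So does whether an amine or a carboxylic acid on the same carbon would give a number inside the assay's range.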